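5-ethylpyrimidin-2-yl for isopropoxycarbonyl: second instance in series

This account rests on a few compounds, and the source may have more. Where it says the series, first, only, none or still open, it means among the compounds named here.

Compound 1 `CC(C)OC(=O)N1CCC(n2ncc3cc(-c4ccc(S(C)(=O)=O)cc4F)ncc32)CC1` and compound 2 `CC(C)OC(=O)N1CCC(n2ncc3cc(-c4cc(F)c(C(=O)NCCO)cc4F)ncc32)CC1` carry different cores; the difference between the two cores is not broken down here. In a functional assay on HEK293 cells for agonist activity at Glucose-dependent insulinotropic receptor (Homo sapiens), read by cAMP accumulation, with a stated time of 30 min (a lower number here means that less compound is needed, a higher number that more compound is needed for the effect), compound 1 gives 27 nM. In this assay compound 2 gives 92 nM, the highest of the three measured numbers, with its steps to compound 1 and to compound 3 both beyond the scatter. Compound 3 `CCc1cnc(N2CCC(n3ncc4cc(-c5ccc(S(C)(=O)=O)cc5F)ncc43)CC2)nc1` is compound 1 with 5-ethylpyrimidin-2-yl in place of isopropoxycarbonyl on an amine nitrogen in a ring. In this assay compound 3 gives 4 nM, so the change produced a 6.8-fold lower number from compound 1 to compound 3 (0.83 log units; beyond the scatter).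

Compound 4 `CCc1cnc(N2CCC(n3ncc4cc(-c5cc(F)c(C(=O)NCCO)cc5F)ncc43)CC2)nc1` has not yet been measured. It is compound 2 with 5-ethylpyrimidin-2-yl in place of isopropoxycarbonyl on an amine nitrogen in a ring. The place of the change reads the same in both pairs, so this is the same change, now made on the core of compound 2 rather than on the core of compound 1. The change has been observed only once, and the two cores are not compared in detail, so the transfer carries uncertainty.

The step from compound 2 to compound 4 in this assay is estimated at a 6.6-fold lower number from compound 2 to compound 4 (0.82 log units; beyond the scatter), because the same change from compound 1 to compound 3 gave a 6.8-fold lower number from compound 1 to compound 3 (0.83 log units; beyond the scatter). For compound 4 in this assay the expected value is 14 nM, with a likely range from 5 nM to 40 nM.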

Compound 4, half-maximal effective concentration: 15 nM
Compound 4: the middle estimate sits 1.1-fold (0.03 log units) below what was measured; the measured number falls inside the stated range.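

In this assay, 5-ethylpyrimidin-2-yl in place of isopropoxycarbonyl on the amine nitrogen in the ring gives a 6.1-fold lower number from compound 2 to compound 4 (0.79 log units; beyond the scatter), and this step agrees with the earlier one: the same change on two cores in this assay, a 6.8-fold lower number (0.83 log units; beyond the scatter) from compound 1 to compound 3 and a 6.1-fold lower number (0.79 log units; beyond the scatter) from compound 2 to compound 4, 1.1-fold (0.04 log units) apart, within the scatter of two such steps. On these two cores, then, the change carries over with its size kept, and the step measured on the core of compound 1 would have served as a fair guide to the step on the core of compound 2. Within the data shown here, the finding rests on only two pairs in a single assay, so it does not show that the step holds on a third core or for other groups at this nitrogen, and it gives no reason why the number falls.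

Still open, as far as these compounds go, is whether a methyl or a propyl group in place of the ethyl on the pyrimidine, or a pyrimidine with no alkyl group at all, would give steps that agree as closely on both cores. Also open, from the compounds shown here alone, is whether the step survives on a core that carries a carboxylic acid in place of the hydroxyethyl amide of compound 4.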